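Aryl amide substituent change: expectation for compound 3

A few compounds are considered here, and "the series" means these few. Any claim that something is new, unique, unknown or untested is made for them only; others in the source may bear on it.

Measured compounds in a functional assay on HT-29 cells (Homo sapiens) for cytotoxicity, read by MTT assay, with a stated time of 72 h; on this read-out higher numbers stand for weaker inhibition and lower numbers for stronger inhibition:
compound 1, `CN1[C@@H]2c3[nH]c4ccccc4c3C[C@H]1[C@H](C#N)N1[C@@H](CNC(=O)c3ccc(Cl)cc3)c3[nH]c4ccccc4c3C[C@@H]21`, gives 130 nM
compound 2, `COc1ccc(C(=O)NC[C@H]2c3[nH]c4ccccc4c3C[C@H]3[C@H]4c5[nH]c6ccccc6c5C[C@@H]([C@H](C#N)N23)N4C)cc1`, gives 840 nM

Going by the values given here, compound 2 stands at the higher of the two numbers in this assay; its nearest neighbour is compound 1, and the change a 6.5-fold higher number from compound 1 to compound 2 (0.81 log units; beyond the scatter) is the only step so far, a modest shift beyond the scatter for one substituent exchanged against another on the aromatic carbon.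

Compound 3, `CCc1ccc(C(=O)NC[C@H]2c3[nH]c4ccccc4c3C[C@H]3[C@H]4c5[nH]c6ccccc6c5C[C@@H]([C@H](C#N)N23)N4C)cc1`, is not yet measured. It differs from compound 2 by ethyl in place of methoxy on an aromatic carbon. Among the compounds with values here, no measured step covers this exchange directly; the single step from compound 1 to compound 2 shows that exchanging the group at this position can move the number by a modest amount in either direction. A step of similar or smaller size, toward a lower number, is therefore expected, a 2.1-fold lower number from compound 2 to compound 3 (0.32 log units; beyond the scatter), with wide uncertainty. Compound 3 is estimated at 400 nM, between 150 nM and 1200 nM.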

Compound 3, half-maximal inhibitory concentration: 3560 nM
The estimate for compound 3 lay 8.9-fold (0.95 log units) below the measured number, and the stated range ends below it.
By their numbers in this assay, from the lowest: compound 1; then compound 2; then compound 3.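

In this assay, ethyl and methoxy have the same heavy-atom count, yet ethyl in place of methoxy gives a 4.2-fold higher number from compound 2 to compound 3 (0.63 log units; beyond the scatter), so heavy-atom count alone does not set the number at this position. Ethyl in place of chloro gives a 27-fold higher number from compound 1 to compound 3 (1.44 log units; beyond the scatter), a large step that shows this position can move the number well beyond the modest shift seen earlier, and both exchanges away from chloro now raise it. No data shown here explain the order chloro, methoxy, ethyl.

Going by these compounds, it remains open whether an amine, a carboxylic acid or fluoro at this place would give a number below that of compound 1 or above that of compound 3. On these data alone, it is also open how a longer chain such as propyl would compare with ethyl.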